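The compounds below may be only part of what the source reports. "The series", "measured", "known", "first", "only" and "open" are said of these compounds alone.

Measured so far in a functional assay on U-251 cells (Homo sapiens) for antiproliferative activity, read by MTT assay, with a stated time of 24 h; a higher number here means a weaker inhibitor, a lower number a stronger inhibitor:
compound 1 `COc1cc(OC)c(-c2coc3cc(OCC=C(C)C)ccc3c2=O)cc1OC`: 3500 nM
compound 2 `COc1ccc2c(=O)c(-c3cc(OC)c(OC)cc3OC)coc2c1`: 9400 nM
compound 3 `COc1cc(OC)c(-c2coc3cc(OCc4ccc(F)cc4)ccc3c2=O)cc1OC`: 3200 nM

Compound 1 stands second highest of the three numbers. Compound 3 sits within the scatter of it, a 1.1-fold lower number from compound 1 to compound 3 (0.04 log units; within the scatter), while compound 2 lies beyond it, a 2.7-fold higher number from compound 1 to compound 2 (0.43 log units; beyond the scatter). Compound 4 `COc1cc(OC)c(-c2coc3cc(OCc4ccc(C#N)cc4)ccc3c2=O)cc1OC` differs from compound 1 by 4-cyanophenyl in place of 2-methylprop-1-en-1-yl on a saturated chain carbon bound to an oxygen on an aromatic ring. Among the compounds with values here, two steps bear on this. The step of a 1.1-fold lower number from compound 1 to compound 3 (0.04 log units; within the scatter) shows that putting an aromatic ring in place of 2-methylprop-1-en-1-yl at this position changed nothing beyond the scatter, and the step of a 2.9-fold lower number from compound 2 to compound 3 (0.47 log units; beyond the scatter) shows that an aromatic ring there does better than hydrogen. A second ring bearing a nitrile is therefore expected to leave the number near that of compound 1. Compound 4 is estimated at 3000 nM, with a range of 1400 nM to 6500 nM. The expected step is a 1.2-fold lower number from compound 1 to compound 4 (0.07 log units; within the scatter), within the scatter.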

Compound 4, half-maximal inhibitory concentration: 6180 nM
Compound 4: middle estimate off by 2.1-fold (0.31 log units), on the low side; low and high end bracket the measured number.
By their numbers in this assay, from the lowest: compounds 3, 1, 4 and 2 (each within the scatter of the next, the first and the last beyond it).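

Cyano in place of fluoro on an aromatic carbon gives a 1.9-fold higher number from compound 3 to compound 4 (0.29 log units; within the scatter), and 4-cyanophenyl in place of 2-methylprop-1-en-1-yl gives a 1.8-fold higher number from compound 1 to compound 4 (0.25 log units; within the scatter). The advantage over hydrogen seen with 4-fluorophenyl does not carry over to every aromatic ring at this position: 4-cyanophenyl in place of hydrogen gives only a 1.5-fold lower number from compound 2 to compound 4 (0.18 log units; within the scatter). No available evidence accounts for these steps.

Open, on these data alone, is whether an amine or a carboxylic acid on the aromatic ring would separate from these values. Also open, as far as these compounds go, is how a longer chain would compare with 3-methylbut-2-en-1-yl.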